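A few compounds are considered here, and "the series" means these few. Any claim that something is new, unique, unknown or untested is made for them only; others in the source may bear on it.

Measured so far:
- compound 1, `NS(=O)(=O)CC(=O)NCCSc1nonc1/C(=N/O)Nc1cccc(Cl)c1`, gives in an ADME assay on microsomes from liver (Homo sapiens) for metabolic stability (a higher number here means that the compound lasts longer, a lower number that the compound disappears faster), the reading > 3 h.
- compound 2, `CS(=O)(=O)NCCSc1nonc1/C(=N/O)Nc1ccc(F)c(Br)c1`, gives in this assay the reading 1.73 h.

Going by the values given here, the two measured compounds share the same core and both carry a sulfur-linked side chain ending in a sulfonamide group, but they differ in more than one place, so the pair yields no single step and its two values can only be set side by side. Compound 1 stands at the limit of > 3 h in this assay, at which 1 of the 2 values shown sits; its reading is a limit of the assay and not a number, so how far beyond that point compound 1 actually lasts is not known. Compound 2 gives a plain number.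

Compound 3, `NS(=O)(=O)CC(=O)NCCSc1nonc1/C(=N/O)Nc1ccc(F)c(C(F)F)c1`, is not yet measured. It is derived from compound 1 by one change: 3-(difluoromethyl)-4-fluorophenyl in place of 3-chlorophenyl on an amine nitrogen. With compound 1 already sitting at the limit, no shift beyond the usual scatter is expected in this assay, so the step from compound 1 to compound 3 is estimated as a number no higher from compound 1 to compound 3 (the limit leaves the size open). Compound 3 is therefore expected to give about 3 h, within a range from 1.5 h to 6 h, with a fair chance that the assay again reports only a limit.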

Compound 3, half-life: 2.77 h
The estimate for compound 3 lay 1.1-fold (0.03 log units) above the measured number; low and high end bracket the measured number.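

In this assay, putting 3-(difluoromethyl)-4-fluorophenyl in place of 3-chlorophenyl on an amine nitrogen gives the first step that can be read among these compounds: an at least 1.0-fold lower number from compound 1 to compound 3 (0.03 log units; that floor lies within the scatter). That figure is only a floor and lies within the scatter, and the true size of the step stays open because compound 1 carries a limit of the assay and not a number: the limit of > 3 h in this assay, at which 1 of the 3 values shown sits.

Even so, the pair shows that an aromatic ring bearing difluoromethyl and fluorine can replace the 3-chlorophenyl group at this place while compound 3 still gives 2.77 h, a plain number against which other groups on this nitrogen can be set.

The compounds shown leave open whether the difluoromethyl group or the added fluorine matters more, since the two enter together in a single change, and whether there is any real drop at all. They also leave open how the same ring would read with trifluoromethyl, a nitrile or a carboxylic acid in place of difluoromethyl.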